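The compounds below may be only part of what the source reports. "The series", "measured", "known", "first", "only" and "open" are said of these compounds alone.

Measured so far in a functional assay on PC-3 cells (Homo sapiens) for inhibition, read by MTT assay, with a stated time of 48 h; on this read-out lower numbers stand for stronger inhibition and higher numbers for weaker inhibition:

Compound 1, `Cn1c(/C=C2\SC(=O)N(CC(=O)N3CCCCC3)C2=O)nc2ccccc21`, gives > 50000 nM, a limit of the assay.
Compound 2, `CCn1c(/C=C2\SC(=O)N(CC(=O)N3CCCC3)C2=O)nc2ccccc21`, gives > 50000 nM, a limit of the assay.
Compound 3, `CC(C)n1c(/C=C2\SC(=O)N(CC(=O)N3CCCC3)C2=O)nc2ccccc21`, gives > 50000 nM, a limit of the assay.

Compound 3 therefore stands at the limit of > 50000 nM in this assay, at which 3 of the 3 values shown sit, and its value is a limit rather than a number; the other two values shown are limits as well. Within the data shown here, the single step between measured compounds that differ in one place, a step that the two limits leave unreadable from compound 2 to compound 3, cannot be read because both of its ends sit at the limit (the limit of > 50000 nM in this assay, at which 3 of the 3 values shown sit). Compound 4, `Cn1c(/C=C2\SC(=O)N(CC(=O)N3CCCC3)C2=O)nc2ccccc21`, differs from compound 3 by methyl in place of isopropyl on an aromatic nitrogen. Among the measured compounds shown here, no measured step with a readable size bears on this change, so the data give no direction for it beyond the scatter. Any expectation rests on compound 3 giving only a limit > 50000 nM. Compound 4 is expected to give 60000 nM, with a range from 20000 nM to 200000 nM, and most probably to be reported as a limit once more. The expected step is a step that the limit leaves unreadable from compound 3 to compound 4, which means no change that the data could resolve.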

Compound 4, half-maximal inhibitory concentration: > 50000 nM
Compound 4: no number, only a limit; the forecaster's own chance of this, stated with the estimate: 85%; the middle value is on the limit's open side.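

No new step can be read for compound 4 against compound 1, compound 2 or compound 3 in this assay, because each of them gives only a limit: the limit of > 50000 nM in this assay, at which 4 of the 4 values shown sit. The compounds shown leave open whether changing the group on the aromatic nitrogen or the pyrrolidin-1-yl and piperidin-1-yl groups has any effect on inhibition, and in which direction.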